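The compounds below may be only part of what the source reports. "The series", "measured", "known", "first", "only" and "open" are said of these compounds alone.

Working notes on the series, read in a functional assay on HCT-116 cells (Homo sapiens) for inhibition, read by MTT assay, with a stated time of 72 h; on this read-out higher numbers stand for weaker inhibition of growth and lower numbers for stronger inhibition of growth. Compound 1 `O=C1COc2ccc(-n3cc(C[C@H](O)COCCOC[C@@H](O)Cc4ccc(-c5ccccc5)cc4)nn3)cc2N1` gives 42500 nM and compound 2 `O[C@H](COCCOC[C@@H](O)Cc1cn(-c2cccs2)nn1)Cc1ccc(-c2ccccc2)cc1` gives 33400 nM, and a 1.3-fold lower number from compound 1 to compound 2 (0.10 log units; within the scatter) keeps these two together. Compound 3 `O[C@H](COCCOC[C@@H](O)Cc1cn(-c2cncnc2)nn1)Cc1ccc(-c2ccccc2)cc1` reads > 100000 nM, which is a limit and not a number. That reading is the limit of > 100000 nM in this assay, at which 1 of the 3 values shown sits, so compound 3 stands at the weak end of the set without a measured value of its own.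

Compound 4 `O[C@H](COCCOC[C@@H](O)Cc1cn(-c2cccnc2)nn1)Cc1ccc(-c2ccccc2)cc1` has pyridin-3-yl in place of pyrimidin-5-yl on an aromatic nitrogen. Within the data shown here, two measured steps bear on this change, as both end at the same pyrimidin-5-yl compound: an at least 2.3-fold higher number from compound 1 to compound 3 (0.37 log units; beyond the scatter) and an at least 2.9-fold higher number from compound 2 to compound 3 (0.47 log units; beyond the scatter). Each is beyond the scatter, and each gives only a minimum size. The two groups that differ from pyrimidin-5-yl thus both sit at lower numbers, although only these two comparisons exist and neither involves pyridin-3-yl.

A modest step to a lower number is therefore expected in this assay, with a second reading at the limit still possible. The expected change is an at least 1.6-fold lower number from compound 3 to compound 4 (0.22 log units; that floor lies within the scatter). The estimate for compound 4 is 60000 nM, with an expected range of 25000 nM to 100000 nM.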

Compound 4, concentration for 50% growth inhibition: 46800 nM
Compound 4: middle estimate off by 1.3-fold (0.11 log units), on the high side; the range from low to high includes it.
By their numbers in this assay, from the lowest: compounds 2, 1 and 4 (each within the scatter of the next). At a limit, above all of these: compound 3.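

In this assay, pyridin-3-yl in place of pyrimidin-5-yl on the aromatic nitrogen, with the heavy-atom count unchanged, gives an at least 2.1-fold lower number from compound 3 to compound 4 (0.32 log units; beyond the scatter) and so brings a measured value back at this position. The remaining comparisons give a 1.4-fold higher number from compound 2 to compound 4 (0.15 log units; within the scatter) and a 1.1-fold higher number from compound 1 to compound 4 (0.04 log units; within the scatter); thiophen-2-yl, pyridin-3-yl and the larger group of compound 1 therefore cannot be told apart here, and among the four compounds only pyrimidin-5-yl separates from the rest. The size of the step from pyrimidin-5-yl to pyridin-3-yl remains a minimum, since the pyrimidin-5-yl compound has no measured value: the limit of > 100000 nM in this assay, at which 1 of the 4 values shown sits.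

The compounds shown cannot say why the second ring nitrogen of pyrimidin-5-yl goes with the weaker reading, nor how far the two pyridin-3-yl and pyrimidin-5-yl compounds truly lie apart. On these data alone, it also stays open whether plain phenyl, pyridin-4-yl, or a ring bearing an amine or a carboxylic acid at this position would give a number clearly below the three measured compounds, which all lie within the scatter of one another.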